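This account rests on a few compounds, and the source may have more. Where it says the series, first, only, none or still open, it means among the compounds named here.

Working notes on the series.

The shared core carries a varying group on one aromatic carbon. Compound 1 `N#Cc1ccc2nc(-c3ccc(-c4ccccc4F)cc3)[nH]c2c1` bears a cyano group there; in an assay on isolated protein for inhibition of acyl-CoA desaturase 1 (Rattus norvegicus) (on this read-out lower numbers stand for stronger inhibition and higher numbers for weaker inhibition), compound 1 reaches only the limit > 20000 nM, which is a limit of the assay and not a number. Compound 2 `NS(=O)(=O)c1ccc2nc(-c3ccc(-c4ccccc4F)cc3)[nH]c2c1` bears a sulfamoyl group, and in this assay compound 2 gives 343 nM. For the measured compounds named here, the single measured step is an at least 58-fold lower number from compound 1 to compound 2 (1.76 log units; beyond the scatter), a change at the core; one of the three values sits at the limit of > 20000 nM in this assay, at which 1 of the 3 values shown sits.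

Compound 3 `CS(=O)(=O)c1ccc2nc(-c3ccc(-c4ccccc4)cc3)[nH]c2c1` carries a methylsulfonyl group on the core and an unsubstituted phenyl on the outer ring; in this assay compound 3 gives 20 nM, the lower of the two numbers, compound 2 standing a long way higher.

Compound 4 `CS(=O)(=O)c1ccc2nc(-c3ccc(-c4ccc(F)cc4)cc3)[nH]c2c1` differs from compound 3 by fluoro in place of hydrogen on an aromatic carbon. Going by the values given here, no measured pair bears on this change: compounds 1 and 2 carry their fluorine on a different position and differ from each other at the core, so they say nothing about the outer ring. The step of no change at the digits printed from compound 3 to compound 4 (within the scatter) is therefore expected to be none beyond the scatter. Compound 4 is estimated at 20 nM, with a range of 8 nM to 50 nM.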

Compound 4, half-maximal inhibitory concentration: 25 nM
Beside the measured number, compound 4's estimate is 1.3-fold (0.10 log units) below it; measured number inside the range.
By their numbers in this assay, from the lowest: compounds 3 and 4 (each within the scatter of the next); then compound 2. At a limit, above all of these: compound 1.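

In this assay, for the compounds shown here, the change gives a 1.3-fold higher number from compound 3 to compound 4 (0.10 log units; within the scatter) and is the first measured step on the outer ring, the step of an at least 58-fold lower number from compound 1 to compound 2 (1.76 log units; beyond the scatter) being a change at the core. With the methylsulfonyl group held on the shared core, phenyl to 4-fluorophenyl therefore keeps the two values within the scatter of each other, so in this one pair fluoro is tolerated on an aromatic carbon para to a large group. Nothing measured here offers an account of this result.

Going by these compounds, whether an amine or a carboxylic acid at the same place would behave like fluoro stays open. On these data alone, compound 2 and compound 3 differ in more than one place, so the effect of the sulfamoyl group against the methylsulfonyl group on the core also stays open.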